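The compounds below may be only part of what the source reports. "The series", "measured", "known", "first", "only" and "open" are said of these compounds alone.

The measured compounds, with their values in a functional assay (trachea) with Rattus norvegicus as the target; a lower number here means a less potent compound, a higher number a more potent compound, by a factor of ten per unit of this negative logarithm:

Compound 1, `CC1(C)C=C(n2ccccc2=O)c2ccccc2O1`, gives 5.05.
Compound 2, `COc1ccc2c(c1)C(n1ccccc1=O)=CC(C)(C)O2`, gives 5.99.
Compound 3, `CC1(C)C=C(n2ccccc2=O)c2cc(C(=O)c3cccs3)ccc2O1`, gives 5.84.

Among these three, compound 3 stands second highest. Its nearest neighbour is compound 2, and the difference between them is within the scatter, so the two cannot be ordered: a number 0.15 log units lower from compound 2 to compound 3 (within the scatter). Its furthest neighbour is compound 1, the compound carrying only hydrogen at that aromatic carbon: a number 0.79 log units higher from compound 1 to compound 3 (beyond the scatter), a modest gain.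

Compound 4, `CC1(C)C=C(n2ccccc2=O)c2cc(C(=O)c3ccc([N+](=O)[O-])cc3)ccc2O1`, keeps the carbonyl on the aromatic carbon and changes only the ring attached to it: 4-nitrophenyl in place of thiophen-2-yl on a carbonyl carbon. The steps measured so far bear on this only indirectly. The step from hydrogen to the thiophenyl carbonyl, a number 0.79 log units higher from compound 1 to compound 3 (beyond the scatter), shows that a carbonyl-linked aromatic group at this position is tolerated with a modest gain, and the step from methoxy to the same group, a number 0.15 log units lower from compound 2 to compound 3 (within the scatter), shows that two quite different substituents there land within the scatter of each other. Within the data shown here, no measured step exchanges one aromatic ring on the carbonyl for another, so the expected effect is small: the value of compound 4 in this assay is estimated to lie within the scatter of compound 3, a step of a number 0.04 log units lower from compound 3 to compound 4 (within the scatter). Compound 4 is therefore expected at 5.8, with a range from 5.2 to 6.4.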

Compound 4, logarithm of the reciprocal of the active concentration, log(1/C): 6.09
Compound 4: the middle estimate sits 0.29 log units below what was measured; measured number inside the range.
By their numbers in this assay, from the lowest: compound 1; then compounds 3, 2 and 4 (each within the scatter of the next).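

Among these compounds, compound 4 gives the first direct exchange of the ring on the carbonyl carbon, and in this assay this change from thiophen-2-yl to 4-nitrophenyl stays within the scatter (a number 0.25 log units higher from compound 3 to compound 4 (within the scatter)). The two compounds therefore cannot be ordered, and the carbonyl-linked position accommodates a five-membered aromatic ring with a hetero atom and a substituted six-membered aromatic ring of carbon only without a readable difference. No supporting measurement on these two rings accompanies the result, so the data offer no explanation for it.

The compounds shown leave open whether a saturated ring such as cyclohexyl or an open chain such as butyl on the carbonyl carbon would fit the same picture. They also leave open whether an amine or a carboxylic acid in place of the nitro group would shift the value, and whether the carbonyl itself could give way to a methylene link.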